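A few compounds are considered here, and "the series" means these few. Any claim that something is new, unique, unknown or untested is made for them only; others in the source may bear on it.

Compound 3 `CC(C)NC(=N)c1ccc2oc(-c3ccc(OCCCCCOc4ccccc4)cc3)cc2c1` gives 20500 nM in an ADME assay on L6 cells (Rattus norvegicus) for cytotoxicity, read by resazurin assay, with a stated time of 70 h (on this read-out higher numbers stand for weaker inhibition and lower numbers for stronger inhibition), the highest of the three numbers in hand. Compound 1 `c1ccc(OCCCOc2ccc(-c3cc4cc(C5=NCCN5)ccc4o3)cc2)cc1` gives 10300 nM, which stays within the scatter of compound 3, whereas compound 2 `c1ccc(OCCCCOc2ccc(-c3cc4cc(C5=NCCN5)ccc4o3)cc2)cc1` gives 2900 nM. Compound 4 `c1ccc(OCCCCCOc2ccc(-c3cc4cc(C5=NCCN5)ccc4o3)cc2)cc1` differs from compound 3 by a group of 5 heavy atoms (3 carbon, 2 nitrogen; one five-membered non-aromatic ring with 2 hetero atoms) in place of a group of 6 heavy atoms (4 carbon, 2 nitrogen; no ring), on an aromatic carbon. Within the data shown here, the only measured step, a 3.6-fold lower number from compound 1 to compound 2 (0.55 log units; beyond the scatter), concerns the chain and not this exchange, so no measured step bears on it directly. Since compounds 1 and 2 carry the group that enters and both give lower numbers than compound 3, compound 4 is expected to show a 2.6-fold lower number from compound 3 to compound 4 (0.41 log units; beyond the scatter). For compound 4 the estimated value is 8000 nM, with a range from 2500 nM to 25000 nM.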

Compound 4, half-maximal inhibitory concentration: 900 nM
For compound 4 the middle estimate is 8.9-fold (0.95 log units) above the measured one, outside the stated range (below it).
By their numbers in this assay, from the lowest: compound 4; then compound 2; then compounds 1 and 3 (each within the scatter of the next).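

In this assay, among these compounds, replacing the open-chain group on the aromatic carbon with the five-membered non-aromatic ring gives a 23-fold lower number from compound 3 to compound 4 (1.36 log units; beyond the scatter), so this position carries a large step that the earlier compounds could not show. With that ring held, the chain step continues with a 3.2-fold lower number from compound 2 to compound 4 (0.51 log units; beyond the scatter), and the two ends of the series give an 11-fold lower number from compound 1 to compound 4 (1.06 log units; beyond the scatter). Nothing shown accounts for these steps. As far as these compounds go, whether the exchange gives a similar step on the shorter chains stays open. So does whether a longer chain would lower the number further, or a carboxylic acid on that aromatic carbon would keep it low.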